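The source may hold more compounds than are shown below. What is called first, only, known or untested is meant among the compounds shown, and "the series" means these compounds.

The account begins with two measured compounds that share a common core and differ at two places. Compound 1 `Nc1nc(CC2CC2)c(-c2ccccc2Br)n1CC(=O)Nc1ccccc1` carries a cyclopropylmethyl chain on the core and a plain phenyl amide; in a functional assay on A-375 cells (Homo sapiens) for antiproliferative activity, read by MTT assay, with a stated time of 48 h (a higher number here means a weaker inhibitor, a lower number a stronger inhibitor), compound 1 gives 5800 nM. Compound 2 `CCCCCCc1nc(N)n(CC(=O)Nc2ccc(C)cc2)c1-c1ccccc1Br` carries a hexyl chain and a methyl-substituted phenyl amide; in this assay compound 2 gives 5100 nM. The two numbers lie within the usual scatter of each other, so compound 2 stands level with compound 1 rather than apart from it.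

Compound 3 `Cc1ccc(NC(=O)Cn2c(N)nc(CC3CC3)c2-c2ccccc2Br)cc1` has not yet been measured. It keeps the amide of compound 2 and takes the chain of compound 1: the change is cyclopropyl in place of pentyl on a saturated chain carbon bound to an aromatic carbon. Since compound 1 and compound 2 show numbers within the scatter of each other despite differing in both chain and amide, the expectation for the step from compound 2 to compound 3 is a 1.1-fold higher number from compound 2 to compound 3 (0.03 log units; within the scatter), no shift beyond the scatter in either direction. Compound 3 is therefore expected to give about 5500 nM in this assay, within a range from 2500 nM to 12000 nM.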

Compound 3, half-maximal inhibitory concentration: 2600 nM
For compound 3 the middle estimate is 2.1-fold (0.33 log units) above the measured one; low and high end bracket the measured number.
By their numbers in this assay, from the lowest: compounds 3, 2 and 1 (each within the scatter of the next, the first and the last beyond it).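

Compounds 1 and 2 differed at two places at once, so neither change could be read alone, and compound 3 now separates them. With the methyl-substituted phenyl amide held fixed, cyclopropyl in place of pentyl on a saturated chain carbon bound to an aromatic carbon gives a 2.0-fold lower number from compound 2 to compound 3 (0.29 log units; within the scatter), so in this assay the exchange of hexyl for cyclopropylmethyl does not move the number clear of the scatter, whereas with the cyclopropylmethyl chain held fixed, methyl in place of hydrogen on an aromatic carbon gives a 2.2-fold lower number from compound 1 to compound 3 (0.35 log units; beyond the scatter), a modest step and the only one of the two that lies beyond the scatter. No measurement at hand bears on why either step has the size it has.

For the compounds shown here, the methyl step is seen only with the cyclopropylmethyl chain, and whether it holds with the hexyl chain remains open. Also open, as far as these compounds go, is what a methoxy group or a chlorine atom would give in place of that methyl, and what an amine or a carboxylic acid at the end of the chain would give.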